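The source may hold more compounds than are shown below. What is called first, only, known or untested is meant among the compounds shown, and "the series" means these compounds.

Compound 2 `COc1ccc(-c2nc(CNC(=O)CSC)sc2-c2ccc(OC)cc2)cc1` is known in a functional assay with Oryctolagus cuniculus as the target (a higher number here means a weaker inhibitor, a lower number a stronger inhibitor), only as a limit, < 100 nM. Compound 1 `COc1ccc(-c2nc(CNC(=O)CSc3ccccc3)sc2-c2ccc(OC)cc2)cc1` likewise reaches only a limit in this assay, < 100 nM. Compound 3 `COc1ccc(-c2nc(CNC(=O)C3=NNC(=O)CC3)sc2-c2ccc(OC)cc2)cc1` gives a number in this assay, 55 nM. Because of the limit of < 100 nM in this assay, at which 2 of the 3 values shown sit, none of the three measured steps can be read: a step that the two limits leave unreadable from compound 1 to compound 2, a step that the limit leaves unreadable from compound 1 to compound 3 and a step that the limit leaves unreadable from compound 2 to compound 3. Compound 4 `CCOC(=O)/C=C/c1nc(-c2ccc(OC)cc2)c(-c2ccc(OC)cc2)s1` differs from compound 2 as follows: 2-(ethoxycarbonyl)ethenyl in place of ((((methylsulfanyl)methyl)carbonyl)amino)methyl on an aromatic carbon. The change removes the whole ((((methylsulfanyl)methyl)carbonyl)amino)methyl group, whereas the measured steps varied only the group on a carbonyl carbon or on a sulfur, so none of them bears directly on it, and their sizes are unreadable in any case. With compound 2 known only as a limit, the expectation for compound 4 is broad and leans toward weaker inhibition, and the step of an at least 3.0-fold higher number from compound 2 to compound 4 (0.47 log units; beyond the scatter) is an estimate only. Compound 4 is expected to give 300 nM in this assay, within 50 nM to 3000 nM.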

Compound 4, half-maximal inhibitory concentration: 20 nM
Compound 4: the middle estimate sits 15-fold (1.18 log units) above what was measured; the whole stated range lies above it.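

In this assay compound 2 stands only as a limit, < 100 nM, so its step to compound 4 cannot be read: the limit of < 100 nM in this assay, at which 2 of the 4 values shown sit. The compounds shown leave open whether, and by how much, 2-(ethoxycarbonyl)ethenyl in place of ((((methylsulfanyl)methyl)carbonyl)amino)methyl changes the number in this assay.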